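The source may report more compounds than this note shows. Statements on the series, on what has been measured and on what is new or still open speak of the compounds shown alone.

Measured compounds:
compound 1, `CN(C)c1cccc(Oc2ccc3c(NCCCNCc4ccco4)ccnc3c2)c1`, 317 10^-6 cm/s
compound 2, `c1ccc(Cc2ccc3c(NCCCNCc4ccco4)ccnc3c2)cc1`, 23 10^-6 cm/s
compound 3, `COc1ccc(F)cc1CNCCCNc1ccnc2cc(Oc3cccc(N(C)C)c3)ccc12`, 317 10^-6 cm/s

Of the compounds shown here, three have been measured in an ADME assay for permeability, using PAMPA, with a stated time of 30 min, at pH 7.4; on this read-out higher numbers stand for higher permeability and lower numbers for lower permeability; a fourth, compound 4 with the structure `COc1ccc(F)cc1CNCCCNc1ccnc2cc(Cc3ccccc3)ccc12`, has not. Compound 1 and compound 3 are built on two cores that differ in one group on the chain: 5-fluoro-2-methoxyphenyl in place of furan-2-yl on a saturated chain carbon bound to an amine nitrogen. In this assay compound 1 gives 317 10^-6 cm/s and compound 3 gives 317 10^-6 cm/s, so that exchange of cores left the number where it was, no change at the digits printed from compound 1 to compound 3 (within the scatter). Compound 2 differs from compound 1 at the other end of the molecule: benzyl in place of 3-(dimethylamino)phenoxy on an aromatic carbon. That step was large, a 14-fold lower number from compound 1 to compound 2 (1.14 log units; beyond the scatter), and compound 2 gives 23 10^-6 cm/s. Compound 4 carries the same exchange relative to compound 3: benzyl in place of 3-(dimethylamino)phenoxy on an aromatic carbon. The place of the exchange is the same in both pairs, word for word, so this is the same change made on the second core. Because the same change made on compound 1 gave the step of a 14-fold lower number from compound 1 to compound 2 (1.14 log units; beyond the scatter), a step of about the same size is expected this time too, a 14-fold lower number from compound 3 to compound 4 (1.14 log units; beyond the scatter). This rests on the two measured pairs alone. Compound 4 is therefore estimated at 23 10^-6 cm/s, with the likely range from 10 10^-6 cm/s to 55 10^-6 cm/s.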

Compound 4, apparent permeability: 23 10^-6 cm/s
Estimate against measurement, compound 4: no gap at the digits printed; measured number inside the range.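

In this assay, putting benzyl in place of 3-(dimethylamino)phenoxy on the second core gave a 14-fold lower number from compound 3 to compound 4 (1.14 log units; beyond the scatter), so the step seen on the first core carried over to the second: the same change on two cores in this assay, a 14-fold lower number (1.14 log units; beyond the scatter) from compound 1 to compound 2 and a 14-fold lower number (1.14 log units; beyond the scatter) from compound 3 to compound 4, 1.0-fold (0.00 log units) apart, within the scatter of two such steps. Read along the other edge of the same set of four compounds, 5-fluoro-2-methoxyphenyl in place of furan-2-yl gave no change at the digits printed from compound 2 to compound 4 (within the scatter), and this exchange left the number unmoved with either group on the aromatic carbon: the same change on two cores in this assay, no change at the digits printed (within the scatter) from compound 1 to compound 3 and no change at the digits printed (within the scatter) from compound 2 to compound 4, 1.0-fold (0.00 log units) apart, within the scatter of two such steps. Within these four compounds, then, the two changes act independently of each other, but that is one pair of cores in one assay, which does not show that the step would carry to a third core, and it does not show which part of the departing group matters, as the two groups differ in both heavy atoms and hydrogen-bond acceptors.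

A plain phenoxy group, which keeps the oxygen and lacks the dimethylamino group, and a 3-(dimethylamino)benzyl group, which keeps the dimethylamino group and lacks the oxygen, would each test one of those parts alone. Also open, going by these compounds, is whether the same step appears on compounds with a longer chain joining the two amine nitrogens.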